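A hexyl chain on the hydroxymethyl carbon of compound 1

This account rests on a few compounds, and the source may have more. Where it says the series, first, only, none or still open, it means among the compounds named here.

Compound 1 `COc1cc(CO)c(OC)c2c1C(=O)C=CC2=O` gives in a functional assay on L1210 cells (Mus musculus) for cytotoxicity (on this read-out lower numbers stand for an effect already at smaller amounts and higher numbers for an effect only at larger amounts of compound), a value of 0.062 ug/mL, the lowest of the three numbers in hand. Among the compounds with values here, compound 2 `CCC(O)C1=CC(=O)c2c(OC)ccc(OC)c2C1=O` gives in this assay a value of 0.516 ug/mL, and compound 3 `CCCCCC(O)C1=CC(=O)c2c(OC)ccc(OC)c2C1=O` gives in this assay a value of 0.378 ug/mL; both numbers stand beyond the scatter above that of compound 1, and both compounds are built differently from compound 1, so no single step joins either of them to it.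

Compound 4 `CCCCCCC(O)c1cc(OC)c2c(c1OC)C(=O)C=CC2=O` differs from compound 1 by hexyl in place of hydrogen on a saturated chain carbon bound to an aromatic carbon and an oxygen on a saturated carbon. Within the data shown here, the one measured step that bears on such a lengthening of a hydroxyalkyl chain is the one from compound 2 to compound 3, namely a 1.4-fold lower number from compound 2 to compound 3 (0.14 log units; within the scatter), which stays within the scatter. On that ground one expects no step beyond the scatter, namely a 1.2-fold higher number from compound 1 to compound 4 (0.08 log units; within the scatter), with no clear direction. The value expected for compound 4 in this assay is therefore 0.075 ug/mL, in a range from 0.03 ug/mL to 0.25 ug/mL.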

Compound 4, concentration for half-maximal effect: 0.22 ug/mL
Compound 4: the middle estimate sits 2.9-fold (0.47 log units) below what was measured; measured number inside the range.
By their numbers in this assay, from the lowest: compound 1; then compounds 4, 3 and 2 (each within the scatter of the next, the first and the last beyond it).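

In this assay the hexyl group on the saturated chain carbon bound to an aromatic carbon and an oxygen on a saturated carbon gives a step beyond the scatter, a 3.5-fold higher number from compound 1 to compound 4 (0.55 log units; beyond the scatter), so on the core of compound 1 this position responds to the added chain. Within the data shown here, the only earlier chain step, a 1.4-fold lower number from compound 2 to compound 3 (0.14 log units; within the scatter), stays within the scatter, and it lies on a differently built pair of compounds, so its flat result does not carry over to this position. No measurement at hand gives a cause for the rise.

A single step leaves open whether a shorter chain such as ethyl or propyl at this carbon would already raise the number, or whether the rise appears only with hexyl. It also leaves open how an amine or a carboxylic acid at the end of the chain would read in this assay.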